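The source may hold more compounds than are shown below. What is called first, only, known or untested is meant among the compounds shown, and "the series" means these compounds.

Measured in a functional assay on K562 cells (Homo sapiens) for inhibition, read by sulforhodamine B assay, with a stated time of 48 h; a higher number here means a weaker inhibitor of growth, a lower number a stronger inhibitor of growth:
Compound 1 `CC1=CC[C@H](C(C)(C)NC(=S)N/N=C/c2ccccc2)CC1` gives 6300 nM.
Compound 2 `CC1=CC[C@H](C(C)(C)NC(=S)N/N=C/c2ccc(O)cc2)CC1` gives only a limit of the assay, > 100000 nM.
Compound 3 `CC1=CC[C@H](C(C)(C)NC(=S)N/N=C/c2ccc(F)cc2)CC1` gives only a limit of the assay, > 100000 nM.

Compound 2 stands at the top edge of what this assay reports: its value is a limit, not a measured number. Compound 3 sits at the same limit (the limit of > 100000 nM in this assay, at which 2 of the 3 values shown sit). Compound 1, which carries hydrogen where compound 2 has hydroxy, is the only one of the three with a measured number; the step of an at least 15-fold higher number from compound 1 to compound 2 (1.20 log units; beyond the scatter) is large, and so is an at least 15-fold higher number from compound 1 to compound 3 (1.20 log units; beyond the scatter). The step that the two limits leave unreadable from compound 2 to compound 3 runs between two limits and is not readable.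

Compound 4 `COc1cc(/C=N/NC(=S)NC(C)(C)[C@H]2CC=C(C)CC2)ccc1O` differs from compound 2 by methoxy in place of hydrogen on an aromatic carbon. For the measured compounds named here, no measured step introduces a methoxy group, so none bears directly on this change; the two large steps show only that each ring substitution measured so far carried the value up to the limit. Compound 4 is therefore expected to stay near that limit, with the step of a number no higher from compound 2 to compound 4 (the limit leaves the size open) expected to read as no change beyond the scatter. The estimate for compound 4 is 100000 nM, in a range from 30000 nM to 300000 nM.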

Compound 4, concentration for 50% growth inhibition: 1900 nM
Estimate against measurement, compound 4: 53-fold (1.72 log units) above, outside the stated range (below it).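

In this assay, methoxy on an aromatic carbon, ortho to a hydroxy group, brings the reading down from the top edge of what is reported: an at least 52-fold lower number from compound 2 to compound 4 (1.72 log units; beyond the scatter). A hydroxy group on this ring therefore does not by itself hold a compound at the limit, and this position can strongly change growth inhibition. Compound 2 gives only a limit and not a measured number, so this step has a known minimum but no fixed size: the limit of > 100000 nM in this assay, at which 2 of the 4 values shown sit.

The compounds shown leave open whether methoxy would have a similar effect on a ring without the hydroxy group, and they do not say why this change matters so much. They also leave open how an ethoxy group, an amine or a chlorine atom would read at the same position.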